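From methyl to methoxy: expected clearance of compound 3

The source may report more compounds than this note shows. Statements on the series, on what has been measured and on what is new or still open speak of the compounds shown alone.

Compound 1 `Cc1cnc(NC(=O)c2cc(Oc3cnc(C(=O)N(C)C)cn3)c3cc(C)oc3c2)cn1`: < 8.5 mL/min/kg
Compound 2 `Cc1cnc(NC(=O)c2cc(Oc3cnc(C(=O)N4CCC4)cn3)c3cc(C)oc3c2)cn1`: < 9.3 mL/min/kg

In an ADME assay (liver) for metabolic stability, with Liver microsome (Homo sapiens) as the target, using microsomes (on this read-out lower numbers stand for slow clearance and higher numbers for fast clearance), compound 1 gives < 8.5 mL/min/kg, which is a limit and not a number. Compound 2 also stands at a limit, < 9.3 mL/min/kg. Compound 3 `COc1cnc(NC(=O)c2cc(Oc3cnc(C(=O)N(C)C)cn3)c3cc(C)oc3c2)cn1` differs from compound 1 by methoxy in place of methyl on an aromatic carbon, with methoxy in place of methyl on an aromatic carbon. Within the data shown here, the only measured step, a step that the two limits leave unreadable from compound 1 to compound 2, is an azetidin-1-yl change at another place, and it gives no size to carry over. Little or no change beyond the scatter is therefore expected in this assay, though a small rise is possible. The estimated step is an at least 1.0-fold higher number from compound 1 to compound 3 (0.02 log units; that floor lies within the scatter). For compound 3 the expected value is 9 mL/min/kg, with an estimated range of 6 mL/min/kg to 16 mL/min/kg.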

Compound 3, clearance: < 8 mL/min/kg
Compound 3 ended at the assay's limit (the forecaster's own chance of this, stated with the estimate: 55%); middle value at least 1.1-fold (0.05 log units) away from the limit.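

In this assay, among these compounds, compound 1 and compound 3 both stand at limits and not at numbers, so no step between them can be read. The compounds shown leave open whether methoxy in place of methyl changes clearance at all.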